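Removing the sulfanyl chain from a chalcone-bearing triazolopyrimidine

A few compounds are considered here, and "the series" means these few. Any claim that something is new, unique, unknown or untested is made for them only; others in the source may bear on it.

For the measured compounds named here, compound 2 `Cc1cc(Nc2ccc(C(=O)/C=C/c3cccc(Br)n3)cc2)n2nc(SCCCc3ccccc3)nc2n1` stands at the lower of the two numbers measured so far: in a functional assay on MGC-803 cells (Homo sapiens) for inhibition, read by sulforhodamine B assay, with a stated time of 72 h, tested at 10 uM (on this read-out lower numbers stand for less inhibition and higher numbers for more inhibition at the one concentration tested (going by the name of the read-out)), compound 2 gives 76.7%, whereas compound 1 `Cc1cc(Nc2ccc(C(=O)/C=C/c3cccc(Br)n3)cc2)n2nc(SCc3ccccc3)nc2n1` gives 90.2%, and the change a number 13.5 percentage points lower from compound 1 to compound 2 (beyond the scatter) lies beyond the scatter. Compound 3 `Cc1cc(Nc2ccc(C(=O)/C=C/c3cccc(Br)n3)cc2)n2ncnc2n1` goes one step further from compound 2: hydrogen in place of (3-phenylpropyl)sulfanyl on an aromatic carbon. Going by the values given here, no measured step matches this removal; the only step recorded concerns the length of the chain, not its absence, and it already lowered inhibition. The account therefore leans toward a further decrease for compound 3, though with wide uncertainty. Compound 3 is expected to reach 55% in this assay, with a plausible range from 25% to 85%. This expected step a number 21.7 percentage points lower from compound 2 to compound 3 (beyond the scatter) would be a decrease beyond the scatter.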

Compound 3, a percentage reported as inhibition, at one concentration (the size of the read-out at that concentration, not a potency): 58.4%
Beside the measured number, compound 3's estimate is 3.4 percentage points below it, within the range that was stated.
By their numbers in this assay, from the lowest: compound 3; then compound 2; then compound 1.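

In this assay the earlier pair varied only the chain on the sulfur, leaving open whether a sulfanyl group on this aromatic carbon matters at all. Replacing (3-phenylpropyl)sulfanyl with hydrogen gives a number 18.3 percentage points lower from compound 2 to compound 3 (beyond the scatter), and replacing benzylsulfanyl with hydrogen gives a number 31.8 percentage points lower from compound 1 to compound 3 (beyond the scatter), so both compounds carrying a sulfanyl chain stand above the one without, though compound 3 still gives 58.4% with only hydrogen at this place. No measurement given here bears on why inhibition falls with this change.

As far as these compounds go, whether the difference rests on the sulfur or on the phenyl ring stays open, and a methylsulfanyl group would separate the two. From the compounds shown here alone, how an amine on this aromatic carbon, or a chain longer than 3-phenylpropyl on the sulfur, would compare also remains open.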